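Cyclic amide replacement on the piperidine carboxamide series

The source may hold more compounds than are shown below. What is called first, only, known or untested is meant among the compounds shown, and "the series" means these compounds.

Measured: compound 1 `CCN(CC)S(=O)(=O)c1ccc(S(=O)(=O)N2CCC[C@@H](C(=O)N[C@@H]3CCN(C(=O)OC(C)(C)C)C3)C2)cc1`, 400 nM; compound 2 `CCN(CC)S(=O)(=O)c1ccc(S(=O)(=O)N2CCC[C@@H](C(=O)N(C)C(C)C)C2)cc1`, 7700 nM.

In a functional assay on BXPC-3 cells (Homo sapiens) for inhibition, read by MTT assay, with a stated time of 7 days (on this read-out lower numbers stand for stronger inhibition and higher numbers for weaker inhibition), compound 2 gives the higher of the two numbers, and its gap to compound 1 lies beyond the usual scatter. Compound 3 `CCN(CC)S(=O)(=O)c1ccc(S(=O)(=O)N2CCC[C@@H](C(=O)NC3CN(C(=O)C4CC4)C3)C2)cc1` carries the change ((1-(cyclopropylcarbonyl)azetidin-3-yl)amino in place of isopropyl(methyl)amino on a carbonyl carbon), which brings back a secondary amide and a saturated nitrogen ring, as in compound 1, whose value is 400 nM. The step of a 9.6-fold lower number from compound 2 to compound 3 (0.98 log units; beyond the scatter) is expected to be a clear drop, beyond the scatter. Compound 3 is estimated at 800 nM, within 250 nM to 3000 nM.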

Compound 3, half-maximal inhibitory concentration: 18500 nM
Estimate against measurement, compound 3: 23-fold (1.36 log units) below; measured number outside the range, above it.
By their numbers in this assay, from the lowest: compound 1; then compound 2; then compound 3.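

In this assay, a secondary amide with a saturated nitrogen ring does not by itself recover the value of compound 1: (1-(cyclopropylcarbonyl)azetidin-3-yl)amino in place of isopropyl(methyl)amino gives a modest loss (a 2.4-fold higher number from compound 2 to compound 3 (0.38 log units; beyond the scatter)). Replacing 1-(tert-butoxycarbonyl)pyrrolidin-3-yl with 1-(cyclopropylcarbonyl)azetidin-3-yl on the amide-type nitrogen costs far more (a 46-fold higher number from compound 1 to compound 3 (1.67 log units; beyond the scatter)), so the value is highly sensitive to this substituent. Nothing available explains either step.

Ring size and the acyl group change together here, and their separate contributions remain open. A 1-(tert-butoxycarbonyl)azetidin-3-yl group or a free ring amine would help separate them.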